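A few compounds are considered here, and "the series" means these few. Any claim that something is new, unique, unknown or untested is made for them only; others in the source may bear on it.

Of the compounds shown here, three built on one shared core have been tested in a functional assay (muscle tissue) with Cavia porcellus as the target; a lower number here means that less compound is needed, a higher number that more compound is needed for the effect. Compound 1 `COC(=O)C1=C(C)N=C(C)/C(=C(\O)OC)C1c1ccc(Cl)cc1` carries a 4-chlorophenyl group on a saturated ring carbon and gives 8130 nM in this assay. Compound 2 `COC(=O)C1=C(C)N=C(C)/C(=C(\O)OC)C1c1cccc(OC(=O)c2ccccc2)c1` gives 6310 nM, a value that lies within the usual scatter of the value of compound 1, so the two cannot be told apart. Compound 3 `COC(=O)C1=C(C)N=C(C)/C(=C(\O)OC)C1c1cccc(Cl)c1Cl` gives 19.1 nM, far below both, and the single-place change from compound 1 to compound 3 shows a 430-fold lower number from compound 1 to compound 3 (2.63 log units; beyond the scatter).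

Compound 4 `COC(=O)C1=C(C)N=C(C)/C(=C(\O)OC)C1c1ccccc1C#N` is the next compound to be measured in this assay. It differs from compound 1 in one place: 2-cyanophenyl in place of 4-chlorophenyl on a saturated ring carbon. Among the measured compounds shown here, only one measured step bears on this, the change from compound 1 to compound 3, which also replaced the 4-chlorophenyl group with a differently substituted phenyl and was large. The new 2-cyanophenyl group is not the group in compound 3, so a step in the same direction but of smaller size is expected for compound 4, namely a 68-fold lower number from compound 1 to compound 4 (1.83 log units; beyond the scatter). Compound 4 is therefore estimated at 120 nM, with a range from 20 nM to 800 nM.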

Compound 4, half-maximal effective concentration: 15.9 nM
Estimate against measurement, compound 4: 7.5-fold (0.88 log units) above; the whole stated range lies above it.
By their numbers in this assay, from the lowest: compounds 4 and 3 (each within the scatter of the next); then compounds 2 and 1 (each within the scatter of the next).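

Replacing the 4-chlorophenyl group with 2-cyanophenyl gives a 510-fold lower number from compound 1 to compound 4 (2.71 log units; beyond the scatter) in this assay and so shows that a large step at this saturated ring carbon does not depend on chlorine. The 2-cyanophenyl and 2,3-dichlorophenyl groups cannot be told apart here, with a 1.2-fold lower number from compound 3 to compound 4 (0.08 log units; within the scatter) as the step between them, so two quite different sets of substituents on the phenyl ring give the same level of result. Nothing available explains why these groups match or why the 4-chlorophenyl group stands so far from them.

From the compounds shown here alone, it remains open whether the nitrile itself matters or only the place it occupies on the phenyl ring. An unsubstituted phenyl group, a 4-cyanophenyl group or a 2-chlorophenyl group at this carbon would help to separate these possibilities.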